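From pentyl to 4-methoxyphenyl on the shared core

The compounds below may be only part of what the source reports. "The series", "measured", "known", "first", "only" and "open" are said of these compounds alone.

Measured in a functional assay on HCT-15 cells (Homo sapiens) for antiproliferative activity, read by MTT assay, with a stated time of 72 h; a lower number here means a stronger inhibitor, a higher number a weaker inhibitor:
- compound 1 `CCCCCn1ccnc1-c1cc(OC)c(OC)c(OC)c1`: > 100000 nM
- compound 2 `COc1cc(-c2nccn2S(=O)(=O)c2ccc(C)cc2)cc(OC)c1OC`: > 100000 nM

Both entries are limits of the assay, not numbers. Compound 1 stands at the limit of > 100000 nM in this assay, at which 2 of the 2 values shown sit. Among the compounds with values here, no measured step exists in this assay, so the size of any change has no direct reference.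

Compound 3 `COc1ccc(-n2ccnc2-c2cc(OC)c(OC)c(OC)c2)cc1` carries 4-methoxyphenyl in place of pentyl on an aromatic nitrogen of the core of compound 1: 4-methoxyphenyl in place of pentyl on an aromatic nitrogen.

With only limits to work from, the expectation is tentative. A real gain in this assay is expected, toward a stronger inhibitor, though a further limit remains quite possible. The expected change is an at least 5.0-fold lower number from compound 1 to compound 3 (0.69 log units; beyond the scatter). For compound 3 the estimated value is 20000 nM, with an expected range from 1000 nM to 100000 nM.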

Compound 3, half-maximal inhibitory concentration: 1300 nM
Compound 3: the middle estimate sits 15-fold (1.19 log units) above what was measured; low and high end bracket the measured number.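

In this assay, within the data shown here, 4-methoxyphenyl in place of pentyl on an aromatic nitrogen gives an at least 76-fold lower number from compound 1 to compound 3 (1.88 log units; beyond the scatter), the first sign that a change at this position can bring measurable antiproliferative activity. Compound 1 gives a limit, not a number, so this step is a minimum and its full size cannot be read. Compound 3 is the only compound in the series with a numerical value, while the other two remain at the limit: the limit of > 100000 nM in this assay, at which 2 of the 3 values shown sit.

On these data alone, whether the gain belongs to the aromatic ring itself or to its methoxy group stays open, and a plain phenyl on the same nitrogen would separate the two. As far as these compounds go, how a 4-aminophenyl or a benzyl group at this position would compare also remains open.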